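This account rests on a few compounds, and the source may have more. Where it says the series, first, only, none or still open, it means among the compounds named here.

Compound 3 `Cn1c(COc2cccc(C(=O)O)c2)nc2ccc(Oc3ccc(Cl)cn3)cc21` is the most soluble of the three compounds measured in a physicochemical assay for solubility, read by HPLC, measured as thermodynamic solubility, with a stated time of 4 h, at pH 6.8 (a higher number here means a more soluble compound, a lower number a less soluble compound), where compound 3 gives 17 ug/mL. Compound 2 `Cc1ccc(Oc2ccc3nc(COc4cccc(C(=O)O)c4)n(C)c3n2)cc1C` gives 16 ug/mL in this assay, within the scatter of compound 3, while compound 1 `Cn1c(COc2cccc(C(=O)O)c2)nc2ccc(Oc3ccc(Cl)c(F)c3)nc21` gives 1.7 ug/mL, well beyond it. Within the data shown here, the only measured single change, a 9.4-fold higher number from compound 1 to compound 2 (0.97 log units; beyond the scatter), swaps one aryl group on the ether oxygen for another and lies beyond the scatter. Compound 4 `Cc1ccnc(Oc2ccc3nc(COc4cccc(C(=O)O)c4)n(C)c3c2)c1` carries 4-methylpyridin-2-yl in place of 5-chloropyridin-2-yl on an oxygen on an aromatic ring. Because the change from compound 1 to compound 2, a 9.4-fold higher number from compound 1 to compound 2 (0.97 log units; beyond the scatter), removed a chlorine and added methyl groups with a gain in solubility, a similar but smaller gain, a 2.1-fold higher number from compound 3 to compound 4 (0.31 log units; beyond the scatter), is expected here. Compound 4 is therefore estimated at 35 ug/mL, with a range of 12 ug/mL to 100 ug/mL.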

Compound 4, solubility: 33 ug/mL
Beside the measured number, compound 4's estimate is 1.1-fold (0.03 log units) above it; the measured number falls inside the stated range.
By their numbers in this assay, from the lowest: compound 1; then compounds 2, 3 and 4 (each within the scatter of the next, the first and the last beyond it).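

In this assay, among these compounds, the pyridine pair gives the first reading of this position with the ring type held constant: 4-methylpyridin-2-yl in place of 5-chloropyridin-2-yl on an oxygen on an aromatic ring gives a 1.9-fold higher number from compound 3 to compound 4 (0.29 log units; within the scatter). This exchange of one group for another with the same count of heavy atoms therefore does not separate the two compounds, whereas the earlier aryl swap, a 9.4-fold higher number from compound 1 to compound 2 (0.97 log units; beyond the scatter), does. Nothing measured here accounts for either result.

The compounds shown leave open whether an amine or a longer chain on the pyridine ring would give a step beyond the scatter. They also leave open whether 4-methylpyridin-2-yl would read the same on the core of compound 1.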